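Replacing sec-butyl with octyl: compound 2 to compound 4

A few compounds are considered here, and "the series" means these few. Any claim that something is new, unique, unknown or untested is made for them only; others in the source may bear on it.

Measured in an ADME assay on Vero cells (Chlorocebus sabaeus) for cytotoxicity, read by MTT assay; a higher number here means a weaker inhibitor, a lower number a stronger inhibitor:
compound 1 `CCCC(C)C(=O)OCC(C)(C)CC1=C(O)C(=O)c2ccccc2C1=O`: 120 nM
compound 2 `CCC(C)CC(=O)OCC(C)(C)CC1=C(O)C(=O)c2ccccc2C1=O`: 2300 nM
compound 3 `CCCCCCC(C)C(=O)OCC(C)(C)CC1=C(O)C(=O)c2ccccc2C1=O`: 450 nM

Compound 2 has the highest number of the three, so it is the weakest inhibitor in this assay, and both of its steps to the others lie beyond the scatter. The next compound, compound 4 `CCCCCCCCCC(=O)OCC(C)(C)CC1=C(O)C(=O)c2ccccc2C1=O`, differs from it by octyl in place of sec-butyl on a saturated chain carbon bound to a carbonyl carbon. Among the measured compounds shown here, the closest precedent is 1-methylheptyl in place of 2-methylbutyl, a 5.1-fold lower number from compound 2 to compound 3 (0.71 log units; beyond the scatter). The step of a 19-fold higher number from compound 1 to compound 2 (1.28 log units; beyond the scatter) shows that this part of the ester can matter strongly, while a 3.8-fold higher number from compound 1 to compound 3 (0.57 log units; beyond the scatter) shows that adding propyl to compound 1 raised the number. For the measured compounds named here, none of the measured compounds carries a nonyl group, so the precedent is only partial. A modest step to a lower number is expected, a 2.9-fold lower number from compound 2 to compound 4 (0.46 log units; beyond the scatter). The estimated value for compound 4 is 800 nM, with an expected range of 250 nM to 2500 nM.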

Compound 4, half-maximal inhibitory concentration: 203000 nM
Beside the measured number, compound 4's estimate is 250-fold (2.40 log units) below it, outside the stated range (above it).
By their numbers in this assay, from the lowest: compound 1; then compound 3; then compound 2; then compound 4.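

In this assay, among the compounds shown here, this position proved able to push the number far beyond anything the earlier compounds reached: octyl in place of sec-butyl on a saturated chain carbon bound to a carbonyl carbon gave a rise (an 88-fold higher number from compound 2 to compound 4 (1.95 log units; beyond the scatter)), whereas 1-methylheptyl on the same ester had lowered the number from compound 2. Nonyl and 1-methylheptyl on a carbonyl carbon were far from interchangeable (a 450-fold higher number from compound 3 to compound 4 (2.65 log units; beyond the scatter)), and nonyl in place of 1-methylbutyl opened the widest gap in the set (a 1700-fold higher number from compound 1 to compound 4 (3.23 log units; beyond the scatter)), leaving compound 4 the weakest inhibitor of the four and the only one whose chain has no methyl branch. Nothing shown here explains this jump. As far as these compounds go, whether the missing branch or the chain length drives it remains open. So does how a longer chain such as dodecyl, or a shorter unbranched one such as butyl, would read.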